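Dimethoxyphenyl for methylphenyl on the oxazole-bearing amide series

This account rests on a few compounds, and the source may have more. Where it says the series, first, only, none or still open, it means among the compounds named here.

Three compounds of the series have been run in a physicochemical assay for solubility, in phosphate buffer, measured as kinetic solubility, at pH 7.4; on this read-out higher numbers stand for higher solubility and lower numbers for lower solubility. Compound 1 `Cc1ccccc1-c1nc(CN2CCC(C(=O)NCCCN3CCC(C)CC3)CC2)c(C)o1` gives a limit of > 67 ug/mL rather than a number. Compound 2 `Cc1cccc(Cl)c1-c1nc(CN2CCC(C(=O)NCCCN3CCCC(C)C3)CC2)c(C)o1` gives 52.6 ug/mL. Compound 3 `Cc1cccc(-c2nc(CN3CCC(C(=O)NCCCN4C[C@H](C)C[C@H](C)C4)CC3)c(C)o2)c1` likewise reaches a limit, > 69 ug/mL, so only a lower bound is known for it; two of the three values shown are limits of this kind (the limit of > 69 ug/mL in this assay, at which 1 of the 3 values shown sits).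

The next compound, compound 4 `COc1cccc(OC)c1-c1nc(CN2CCC(C(=O)NCCCN3C[C@H](C)C[C@H](C)C3)CC2)c(C)o1`, carries 2,6-dimethoxyphenyl in place of 3-methylphenyl on an aromatic carbon. Among the compounds with values here, no measured step of this kind exists among the three compounds, so the expected step that the limit leaves unreadable from compound 3 to compound 4 is taken as none beyond the scatter in this assay. Compound 4 is accordingly estimated at 70 ug/mL, with a range from 40 ug/mL to 110 ug/mL, and a limit again is expected to be likely.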

Compound 4, solubility: > 76 ug/mL
Compound 4 ended at the assay's limit; the forecaster's own chance of this, stated with the estimate: 55%; middle value at least 1.0-fold (0.03 log units) from the limit.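

In this assay compound 3 and compound 4 both end at limits, and no step can be read between them. Still open, going by these compounds, is whether 2,6-dimethoxyphenyl in place of 3-methylphenyl shifts the read-out at all.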